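The compounds below may be only part of what the source reports. "The series", "measured", "known", "first", "only" and "open" are said of these compounds alone.

Of the compounds shown here, three built on one shared core have been tested in a functional assay on PC-3 cells (Homo sapiens) for inhibition; on this read-out higher numbers stand for weaker inhibition and lower numbers for stronger inhibition. Compound 1 `COc1cc2nc(N3CCN(S(=O)(=O)c4cccc([N+](=O)[O-])c4)CC3)nc(N)c2cc1OC` gives 32000 nM, compound 2 `COc1cc2nc(N3CCN(S(=O)(=O)c4ccc(C)cc4)CC3)nc(N)c2cc1OC` gives 30000 nM, and compound 3 `COc1cc2nc(N3CCN(S(=O)(=O)c4ccc(C(F)(F)F)cc4)CC3)nc(N)c2cc1OC` gives 27000 nM. The step of a 1.2-fold lower number from compound 1 to compound 3 (0.07 log units; within the scatter) and the step of a 1.1-fold lower number from compound 2 to compound 3 (0.05 log units; within the scatter) both fall within the scatter, so compound 3 stands together with compounds 1 and 2 rather than apart from them. Compound 4 `COc1cc2nc(N3CCN(S(=O)(=O)c4ccc(OC(F)(F)F)cc4)CC3)nc(N)c2cc1OC` has not yet been measured; it differs from compound 3 by trifluoromethoxy in place of trifluoromethyl on an aromatic carbon. The measured step most like this one is a 1.1-fold lower number from compound 2 to compound 3 (0.05 log units; within the scatter), which exchanged one group for another on the same aromatic carbon and left the number within the scatter; the step of a 1.1-fold lower number from compound 1 to compound 2 (0.03 log units; within the scatter) likewise stayed within the scatter. For the measured compounds named here, nothing among the measured compounds points to a step beyond the scatter for a change at this place, so in this assay no direction is expected. Compound 4 is therefore estimated at 27000 nM, within 12000 nM to 60000 nM, which means an expected step of no change at the digits printed from compound 3 to compound 4 (within the scatter).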

Compound 4, half-maximal inhibitory concentration: 25000 nM
Compound 4: middle estimate off by 1.1-fold (0.03 log units), on the high side, within the range that was stated.
By their numbers in this assay, from the lowest: compounds 4, 3, 2 and 1 (each within the scatter of the next).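

In this assay, putting an oxygen into the group on this aromatic carbon, para to a large group, gives a 1.1-fold lower number from compound 3 to compound 4 (0.03 log units; within the scatter), so trifluoromethoxy stands together with trifluoromethyl here. The wider comparisons agree, with a 1.2-fold lower number from compound 2 to compound 4 (0.08 log units; within the scatter) and a 1.3-fold lower number from compound 1 to compound 4 (0.11 log units; within the scatter), the last of these also changing where the substituent sits on the phenyl ring; across the four aryl sulfonyl groups shown, no exchange leaves the scatter. No supporting evidence is available to explain this result.

The compounds shown leave open whether an amine or a carboxylic acid on this aromatic carbon would give a step beyond the scatter. They also leave open whether replacing the phenyl ring on the sulfonyl sulfur with a longer alkyl chain would change the number.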